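Swapping the cyclohexyl acid group: what half-life to expect

The source may report more compounds than this note shows. Statements on the series, on what has been measured and on what is new or still open speak of the compounds shown alone.

Compound 1 `COc1ccc(F)cc1-c1c(F)cnc2[nH]c(C3=CCN([C@H]4CC[C@H](C(=O)O)CC4)CC3)cc12` – 3.5 h
Compound 2 `COc1ccc(F)cc1-c1c(F)cnc2[nH]c(C3=CCN([C@H]4CC[C@@H](C(=O)O)CC4)CC3)cc12` – 3 h

In an ADME assay on the whole organism (Rattus norvegicus) for metabolic stability, at a dose of 1 mg/kg by the intravenous route (a lower number here means that the compound disappears faster, a higher number that the compound lasts longer), compound 2 gives 3 h and stands within the scatter of compound 1 (3.5 h). Compound 3 `COc1ccc(F)cc1-c1c(F)cnc2[nH]c(C3=CCN([C@H]4CC[C@H](CC(=O)O)CC4)CC3)cc12` carries 4-(carboxymethyl)cyclohexyl in place of 4-carboxycyclohexyl on an amine nitrogen in a ring. Among the compounds with values here, the only measured step stays within the scatter (a 1.2-fold lower number from compound 1 to compound 2 (0.07 log units; within the scatter)), and it concerns a different kind of change (the fact that compounds 1 and 2 differ only in the configuration as drawn). Within the data shown here, no measured step replaces this group, so that step is only a weak guide. The estimate therefore starts from compound 2 (3 h). The expected change is nothing beyond the scatter, in either direction (no change at the digits printed from compound 2 to compound 3 (within the scatter)). The half-life expected in this assay for compound 3 is 3 h (estimated range 1.4 h to 6.5 h).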

Compound 3, half-life: 2.8 h
Compound 3: the middle estimate sits 1.1-fold (0.03 log units) above what was measured; the measured number falls inside the stated range.
By their numbers in this assay, from the lowest: compounds 3, 2 and 1 (each within the scatter of the next).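

In this assay, 4-(carboxymethyl)cyclohexyl in place of 4-carboxycyclohexyl on an amine nitrogen in a ring gives a 1.1-fold lower number from compound 2 to compound 3 (0.03 log units; within the scatter), and carboxymethyl in place of carboxy on a saturated ring carbon gives a 1.3-fold lower number from compound 1 to compound 3 (0.10 log units; within the scatter). For these three compounds, then, changing the acid-bearing group in this way leaves the half-life within the scatter, whichever of the two carboxy compounds serves as the starting point. The earlier comparison could speak only to a different kind of change: the fact that compounds 1 and 2 differ only in the configuration as drawn

Still open, from the compounds shown here alone, is whether the half-life stays the same when the carboxylic acid gives way to another group, such as a primary amide or an amine, or when a longer chain carries the acid. The compounds shown also leave open how the other drawn configuration of the carboxymethyl group would compare with compound 3.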